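Propyl for Isopropyl on the Amine: Cytotoxicity Stays Beyond Limit

This account rests on a few compounds, and the source may have more. Where it says the series, first, only, none or still open, it means among the compounds named here.

compound 1 `CCOC(=O)CCCCCOc1cccc(CNC(C)C)c1`: > 26000 nM
compound 2 `CCOC(=O)CCCCCOc1ccc(CNC(C)C)cc1`: > 26000 nM
compound 3 `CCCNCc1cccc(OCCCCCC(=O)OCC)c1`: > 26000 nM

In an ADME assay on HepG2 cells (Homo sapiens) for cytotoxicity, read by CellTiter-Glo and resazurin assay, with a stated time of 72 h (a higher number here means that more compound is needed for the effect, a lower number that less compound is needed), each of these three values is a limit of the assay and not a number, as the limit of > 26000 nM in this assay, at which 3 of the 3 values shown sit, shows. Compound 1 and compound 3 differ by propyl in place of isopropyl on an amine nitrogen, and the step that the two limits leave unreadable from compound 1 to compound 3 cannot be sized because both sit at the limit. The difference between the core of compound 1 and the core of compound 2 is not broken down here.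

Compound 4 `CCCNCc1ccc(OCCCCCC(=O)OCC)cc1` is not yet measured; it differs from compound 2 by propyl in place of isopropyl on an amine nitrogen, the same change as from compound 1 to compound 3. Since a step that the two limits leave unreadable from compound 1 to compound 3 left the value at the limit, compound 4 is expected to show a step that the limit leaves unreadable from compound 2 to compound 4 in this assay. The estimate for compound 4 is 40000 nM, between 26000 nM and 120000 nM.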

Compound 4, half-maximal effective concentration: > 26000 nM
Compound 4: only a limit was reported (the forecaster's own chance of this, stated with the estimate: 85%); the middle value does not contradict the limit.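

No step can be read from compound 2 to compound 4, since both stand at a limit and not at a number in this assay: the limit of > 26000 nM in this assay, at which 4 of the 4 values shown sit.

The compounds shown leave open where their true values lie and whether propyl in place of isopropyl changes cytotoxicity at all.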